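The source may hold more compounds than are shown below. What is called first, only, known or untested is meant among the compounds shown, and "the series" means these compounds.

Measured so far in an assay on MDA-MB-231 cells for binding affinity to C-X-C chemokine receptor type 4 (Homo sapiens), read by microscopy, with stated times of 10 min and 30 min; on this read-out lower numbers stand for an effect already at smaller amounts and higher numbers for an effect only at larger amounts of compound:
- compound 1 `Cc1cccc(S(=O)(=O)NCc2ccc(CNC(=O)c3ccc(CNc4ncccn4)cc3)cc2)c1`: 100 nM
- compound 2 `O=C(NCc1ccc(CNS(=O)(=O)c2cccc(C(F)(F)F)c2)cc1)c1ccc(CNc2ncccn2)cc1`: 1000 nM
- compound 3 `O=C(NCc1ccc(CNS(=O)(=O)c2cccc(Cl)c2)cc1)c1ccc(CNc2ncccn2)cc1`: 1 nM

Compound 3 stands lowest of the three numbers in this assay. The steps that lead to it are large: a 100-fold lower number from compound 1 to compound 3 (2.00 log units; beyond the scatter) and a 1000-fold lower number from compound 2 to compound 3 (3.00 log units; beyond the scatter), both beyond the scatter. The remaining step between the measured compounds, a 10-fold higher number from compound 1 to compound 2 (1.00 log units; beyond the scatter), is modest but also beyond the scatter. All three steps change the same aromatic carbon of the sulfonyl-bearing ring, so this position is where the series moves most.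

Compound 4 `O=C(NCc1ccc(CNS(=O)(=O)c2cccc(F)c2)cc1)c1ccc(CNc2ncccn2)cc1` is the next variation at that position: fluoro in place of chloro on an aromatic carbon. Among the measured compounds shown here, no measured step here carries fluoro, so nothing bears directly on it; what the three steps do show is that any exchange at this carbon has so far shifted the number well beyond the scatter, and that chloro gave the lowest number of the three groups tried. On that basis an upward step in this assay from compound 3 to compound 4 is expected, larger than the scatter but with wide uncertainty, since the only anchor is the sensitivity of the position itself. The expected step is a 30-fold higher number from compound 3 to compound 4 (1.48 log units; beyond the scatter). For compound 4 the estimate in this assay is 30 nM, with a range from 3 nM to 300 nM.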

Compound 4, effective concentration (reported as EC, without a stated level of effect): 1000 nM
For compound 4 the middle estimate is 33-fold (1.52 log units) below the measured one; measured number outside the range, above it.
By their numbers in this assay, from the lowest: compound 3; then compound 1; then compounds 2 and 4 (each within the scatter of the next).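

In this assay the exchange gives a 1000-fold higher number from compound 3 to compound 4 (3.00 log units; beyond the scatter) although the computed counts of heavy atoms, rings, hydrogen-bond donors, hydrogen-bond acceptors and net charge are the same for chloro and fluoro, so those counts do not separate the two groups and the low number of compound 3 does not carry over to the other single-atom halogen. Fluoro and trifluoromethyl are not told apart on this read-out, with no change at the digits printed from compound 2 to compound 4 (within the scatter) and with a 10-fold higher number from compound 1 to compound 4 (1.00 log units; beyond the scatter) as well, so among the four groups tried at this aromatic carbon only chloro reaches the low end, while methyl stands apart from both chloro and the fluoro and trifluoromethyl pair. Nothing measured alongside these numbers accounts for the gap between chloro and fluoro.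

As far as these compounds go, whether the low number is particular to chloro or extends to bromo, methoxy or a nitrile on this same carbon remains open. Also open, from the compounds shown here alone, is whether chloro keeps the number of compound 3 on another carbon of the same ring, and whether the order of the four compounds holds on any read-out other than this one.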